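A few compounds are considered here, and "the series" means these few. Any claim that something is new, unique, unknown or untested is made for them only; others in the source may bear on it.

Compound 1 `Cc1nc(N2CCN(C)CC2)c2nc(-c3cccc(C(F)(F)F)c3)n(C3CCOCC3)c2n1`: 19%
Compound 2 `COc1ccccc1-c1nc2c(N3CCN(C)CC3)nc(C)nc2n1C1CCOCC1`: 22%
Compound 3 `COc1cccc(-c2nc3c(N4CCN(C)CC4)nc(C)nc3n2C2CCOCC2)c1`: 40%

In an ADME assay (liver) for metabolic stability, with Liver microsome (Homo sapiens) as the target, read by LC-MS, using microsomes, with a stated time of 30 min, tested at 4 uM (on this read-out higher numbers stand for a more stable compound and lower numbers for a less stable compound), compound 3 gives the highest of the three numbers, with both others lower beyond the scatter. Compound 4 `Cc1nc(N2CCN(C)CC2)c2nc(-c3ccccc3F)n(C3CCOCC3)c2n1` is unmeasured. The change is 2-fluorophenyl in place of 3-methoxyphenyl on an aromatic carbon, with 2-fluorophenyl in place of 3-methoxyphenyl on an aromatic carbon. Among the compounds with values here, no measured compound carries 2-fluorophenyl. Its nearest match is the 2-methoxyphenyl group of compound 2, at 22%. The relevant steps are a number 18 percentage points higher from compound 2 to compound 3 (beyond the scatter) and a number 21 percentage points higher from compound 1 to compound 3 (beyond the scatter), both modest, while a number 3 percentage points higher from compound 1 to compound 2 (within the scatter) stays within the scatter. A modest fall is therefore expected, and the estimated change is a number 13 percentage points lower from compound 3 to compound 4 (beyond the scatter). For compound 4 the expected value is 27%, with an estimated range of 14% to 43%.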

Compound 4, percent of the compound remaining: 10%
For compound 4 the middle estimate is 17 percentage points above the measured one; measured number below the stated range.
By their numbers in this assay, from the lowest: compounds 4, 1 and 2 (each within the scatter of the next, the first and the last beyond it); then compound 3.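

In this assay the 2-fluorophenyl group gives the largest step at this position, a number 30 percentage points lower from compound 3 to compound 4 (beyond the scatter), so the higher reading with 3-methoxyphenyl does not carry over to this aryl group. With the substituent on the same ring carbon, fluoro in place of methoxy still counts, at a number 12 percentage points lower from compound 2 to compound 4 (beyond the scatter), while a number 9 percentage points lower from compound 1 to compound 4 (within the scatter) stays within the scatter. No measured data bear on the reason for these steps.

Open, from the compounds shown here alone, is how unsubstituted phenyl or 3-fluorophenyl would read here. Those groups would help separate the identity of the substituent from its place on the ring.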